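Methoxy added to the anilino-chalcone pyrazole of compound 1

A few compounds are considered here, and "the series" means these few. Any claim that something is new, unique, unknown or untested is made for them only; others in the source may bear on it.

Compound 1, `COc1ccc(-c2cc(/C=C/C(=O)c3ccc(N)cc3)[nH]n2)cc1`, was tested in a functional assay on OVCAR-5 cells (Homo sapiens) for cytotoxicity, read by sulforhodamine B assay, with a stated time of 48 h, tested at 10 uM (a lower number here means a stronger effect, a higher number a weaker effect of the compound at the concentration tested), where compound 1 gives -41%. That is the highest of the two numbers recorded in this assay. Among the measured compounds shown here, the only other measured compound, compound 2, `COc1ccc(C(=O)/C=C/c2cc(-c3cc(OC)c(OC)c(OC)c3)n[nH]2)cc1OC`, gives -93% in this assay, a number well beyond the usual scatter away from the value of compound 1; compound 2 differs from compound 1 in several places at once, so no single step between the two is available.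

Compound 3, `COc1ccc(-c2cc(/C=C/C(=O)c3ccc(N)cc3)[nH]n2)cc1OC`, has not yet been measured. It differs from compound 1 by methoxy in place of hydrogen on an aromatic carbon, the new group sitting ortho to a methoxy group already present on the six-membered aromatic ring.

For the measured compounds named here, with no measured step of this kind to draw on, the size of the step is uncertain. The account expects the step of a number 9 percentage points lower from compound 1 to compound 3 (within the scatter) in this assay to be small and toward a lower number, possibly not beyond the scatter. Compound 3 is therefore estimated at -50%, within a range from -80% to -20%.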

Compound 3, a percentage reported as activity, at one concentration (the size of the read-out at that concentration, not a potency): -10%
Estimate against measurement, compound 3: 40 percentage points below; the measured number lies above the stated range.
By their numbers in this assay, from the lowest: compound 2; then compound 1; then compound 3.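

In this assay, among the compounds shown here, the step of a number 31 percentage points higher from compound 1 to compound 3 (beyond the scatter) is the first change in a single place that can be read, and it shows that this position is not indifferent to substitution. Methoxy in place of hydrogen on this aromatic carbon, ortho to a methoxy group and meta to a large group, moves the number toward a weaker effect of the compound at the concentration tested, and the move lies beyond the usual scatter. No measurement shown here bears on why the step goes in this direction or has this size.

The compounds shown leave open whether a hydroxy group, a fluorine atom or an ethoxy group in the same place would give a step of similar size and direction, and so whether the step belongs to methoxy or to substitution at this place in general. They also leave open whether methoxy would give the same step in this place if the amine on the other aromatic ring were replaced by a carboxylic acid.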